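Removing a methyl from the acyl side chain of compound 3

The compounds below may be only part of what the source reports. "The series", "measured", "known", "first", "only" and "open" are said of these compounds alone.

Compound 3, `CCC(=O)c1ccc2c(c1O)[C@H]1c3c(ccc4c(=O)c(C)coc34)OC[C@H]1C(C)(C)O2`, is known in a functional assay on MDA-MB-231 cells (Homo sapiens) for cytotoxicity, read by MTT assay (on this read-out higher numbers stand for weaker inhibition and lower numbers for stronger inhibition), only as a limit: it gives > 100000 nM. Compound 1, `CC(=O)c1ccc2c(c1O)[C@@H]1c3c(ccc4c(=O)c(C)c(C)oc34)OC[C@@H]1C(C)(C)O2`, gives > 100000 nM, also a limit. Compound 2, `Cc1oc2c3c(ccc2c(=O)c1C)OC[C@H]1[C@@H]3c2c(ccc(C(=O)c3ccccc3)c2O)OC1(C)C`, gives > 100000 nM, again a limit. Within the data shown here, the single measured step, a step that the two limits leave unreadable from compound 1 to compound 2, therefore cannot be sized, since both ends sit at the limit of > 100000 nM in this assay, at which 3 of the 3 values shown sit. Compound 4, `CC(=O)c1ccc2c(c1O)[C@H]1c3c(ccc4c(=O)c(C)coc34)OC[C@H]1C(C)(C)O2`, differs from compound 3 by hydrogen in place of methyl on a saturated chain carbon bound to a carbonyl carbon. Among the measured compounds shown here, no measured step touches this part of the structure, so the only bearing evidence is that every compound so far, including compound 3, sits at the same limit in this assay. No step beyond the scatter is expected in this assay from this change; the series gives no sign that a small change at the acyl chain moves the read-out into the measurable range. Compound 4 is therefore expected to sit at about 150000 nM, within 70000 nM to 350000 nM, most likely reported again as a limit. The step that the limit leaves unreadable from compound 3 to compound 4 is estimated to lie within the scatter.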

Compound 4, half-maximal inhibitory concentration: > 100000 nM
Compound 4: no number, only a limit (the forecaster's own chance of this, stated with the estimate: 85%); the middle value does not contradict the limit.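

The step from compound 3 to compound 4 cannot be read in this assay, since both compounds are known only as limits: the limit of > 100000 nM in this assay, at which 4 of the 4 values shown sit.

The compounds shown leave open whether any change to the acyl side chain or the shared core brings a measurable value in this assay.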